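From furan-2-yl to benzyloxy on a carbonyl carbon

This account rests on a few compounds, and the source may have more. Where it says the series, first, only, none or still open, it means among the compounds named here.

Going by the values given here, in a functional assay on L5178Y cells (Mus musculus) for inhibition, read by MTT assay, with a stated time of 24 h (on this read-out higher numbers stand for weaker inhibition and lower numbers for stronger inhibition), compound 3 `COc1ccc([C@@H]2C/C(=N\NC(=O)c3ccco3)c3c(O)cc(OC)cc3O2)cc1` gives 2700 nM, the lowest number so far. Compound 2 `COc1ccc([C@@H]2C/C(=N\Nc3ccc(Br)cn3)c3c(O)cc(OC)cc3O2)cc1` gives 8000 nM. Compound 1 `COc1ccc([C@@H]2C/C(=N\N)c3c(O)cc(OC)cc3O2)cc1` reads >= 11300 nM, which is a limit of the assay. Compound 4 `COc1ccc([C@@H]2C/C(=N\NC(=O)OCc3ccccc3)c3c(O)cc(OC)cc3O2)cc1` carries benzyloxy in place of furan-2-yl on a carbonyl carbon, (benzyloxy in place of furan-2-yl on a carbonyl carbon). The steps on the amine nitrogen bear on this only indirectly: an at least 4.1-fold lower number from compound 1 to compound 3 (0.62 log units; beyond the scatter), a 3.0-fold lower number from compound 2 to compound 3 (0.47 log units; beyond the scatter) and an at least 1.4-fold lower number from compound 1 to compound 2 (0.14 log units; that floor lies within the scatter), the last with a floor within the scatter. None of them alters the group on the carbonyl carbon. The step expected in this assay is a 1.5-fold higher number from compound 3 to compound 4 (0.17 log units; within the scatter), toward a slightly higher number but within the scatter. For compound 4 the estimated value is 4000 nM, with an expected range of 1500 nM to 11000 nM.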

Compound 4, half-maximal inhibitory concentration: > 100000 nM
Compound 4: a limit, no number; the forecaster's own chance of this, stated with the estimate: 15%; at least 25-fold (1.39 log units) between middle value and limit.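

The earlier compounds shown here never varied the group on the carbonyl carbon, and here benzyloxy in place of furan-2-yl gives an at least 37-fold higher number from compound 3 to compound 4 (1.56 log units; beyond the scatter). A carbonyl on the amine nitrogen therefore does not by itself bring a low number, as benzyloxycarbonyl in place of 5-bromopyridin-2-yl gives an at least 12-fold higher number from compound 2 to compound 4 (1.09 log units; beyond the scatter). Compound 4 stands as a limit and not as a number: the limit of > 100000 nM in this assay, at which 1 of the 4 values shown sits.

The step from compound 1 to compound 4 cannot be read. On these data alone, whether benzyl or thiophen-2-yl on the carbonyl carbon would read nearer to compound 3 or to compound 4 stays open.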